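Moving a methyl onto a phenolic oxygen in two related cores

The compounds below may be only part of what the source reports. "The series", "measured", "known", "first", "only" and "open" are said of these compounds alone.

Compound 1 `COc1ccc(/C=C2\Cc3c(cc(OC)c(OC)c3OC)C2=O)cc1O`: 172 nM
Compound 2 `COc1ccc(/C=C2\Cc3c(cc(OC)c(OC)c3OC)C2=O)cc1OC`: 8560 nM
Compound 3 `COc1cc2c(cc1O)C(=O)/C(=C/c1ccc(OC)c(OC)c1OC)C2`: 1590 nM

In a functional assay on HeLa cells (Homo sapiens) for antiproliferative activity, read by MTT assay, with a stated time of 48 h (a lower number here means a stronger inhibitor of growth, a higher number a weaker inhibitor of growth), compound 1 gives 172 nM, and compound 2 gives 8560 nM. The two differ by methyl in place of hydrogen on an oxygen on an aromatic ring, and this change brought a 50-fold higher number from compound 1 to compound 2 (1.70 log units; beyond the scatter). Compound 3 shares its atoms with compound 1 but has them joined differently; the difference between the two cores is not broken down here. Compound 3 gives 1590 nM in this assay. Compound 4 `COc1cc2c(cc1OC)C(=O)/C(=C/c1ccc(OC)c(OC)c1OC)C2` is not yet measured; it differs from compound 3 by methyl in place of hydrogen on an oxygen on an aromatic ring, the same change seen from compound 1 to compound 2. Because a 50-fold higher number from compound 1 to compound 2 (1.70 log units; beyond the scatter) was large, the step from compound 3 to compound 4 is expected to be a 25-fold higher number from compound 3 to compound 4 (1.40 log units; beyond the scatter), though a second core gives no guarantee of the same size. Compound 4 is therefore estimated at 40000 nM, between 8000 nM and 200000 nM.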

Compound 4, concentration for 50% growth inhibition: > 10000 nM
Compound 4: a limit, no number; the forecaster's own chance of this, stated with the estimate: 25%; the middle value lies beyond the limit too.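

In this assay compound 4 gives > 10000 nM, which is a limit of the assay and not a number. Replacing hydroxy with methoxy brought an at least 6.2-fold higher number from compound 3 to compound 4 (0.79 log units; beyond the scatter), so the growth-inhibition number rose on this second core, as it did on the core of compound 1. This shows that the direction of the change carried over between these two cores, but it does not show that the size did: the same change on two cores in this assay, a 50-fold higher number (1.70 log units; beyond the scatter) from compound 1 to compound 2 and an at least 6.2-fold higher number (0.79 log units; beyond the scatter) from compound 3 to compound 4; the limit leaves it open whether they differ

The compounds shown carry only hydroxy or methoxy at this place, so it remains open how an ethoxy group, a longer chain on the oxygen or an amine would read in this assay. Two cores also leave open whether the same direction would hold on any other core.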